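Sulfonyl substituent change and microsomal clearance

The source may report more compounds than this note shows. Statements on the series, on what has been measured and on what is new or still open speak of the compounds shown alone.

Measured so far:
compound 1 `COc1cc(-c2nnc(S(=O)(=O)C3CCC3)[nH]2)ccc1-c1cnc(OCC(C)C)c(Cl)c1` — 59 uL/min
compound 2 `CC(C)COc1ncc(-c2cc(F)c(-c3nnc(S(=O)(=O)NC4CC4)[nH]3)cc2F)cc1Cl` — 125 uL/min

In an ADME assay on microsomes from liver (Homo sapiens) for metabolic stability (on this read-out higher numbers stand for fast clearance and lower numbers for slow clearance), compound 2 gives 125 uL/min, the higher of the two numbers, and compound 1 gives 59 uL/min, a gap beyond the scatter. Compound 3 `CC(C)COc1ncc(-c2cc(F)c(-c3nnc(S(C)(=O)=O)[nH]3)cc2F)cc1Cl` is still to be measured. Compared with compound 2 it differs in one place: methyl in place of cyclopropylamino on a sulfonyl sulfur. For the measured compounds named here, no pair of measured compounds shows this change, so the step is a guess resting on two points. The step from compound 2 to compound 3 is expected to be a 1.8-fold lower number from compound 2 to compound 3 (0.25 log units; within the scatter), a decrease beyond the scatter. Compound 3 is estimated at 70 uL/min, expected between 35 uL/min and 140 uL/min.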

Compound 3, intrinsic clearance in a liver preparation (reported as CLH), per the amount of preparation that the assay uses: 41 uL/min
The estimate for compound 3 lay 1.7-fold (0.23 log units) above the measured number, within the range that was stated.
By their numbers in this assay, from the lowest: compounds 3 and 1 (each within the scatter of the next); then compound 2.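

In this assay, for the compounds shown here, methyl in place of cyclopropylamino on a sulfonyl sulfur gives a 3.0-fold lower number from compound 2 to compound 3 (0.48 log units; beyond the scatter) and is the first change seen on its own. The group on the sulfonyl sulfur therefore moves this read-out with the shared core held constant. No measurement at hand accounts for the step.

From the compounds shown here alone, whether the same step holds on the core of compound 1 remains open. Also open, going by these compounds, is how a plain amino group, an ethyl or a longer chain on the sulfonyl sulfur would read.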